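Bis-sulfonylmethyl amines: hexyl to benzyl on the nitrogen

A few compounds are considered here, and "the series" means these few. Any claim that something is new, unique, unknown or untested is made for them only; others in the source may bear on it.

The series is followed in an assay on CHO cells for displacement of a labelled ligand from melanin-concentrating hormone receptor 1 (Homo sapiens); on this read-out higher numbers stand for weaker inhibition and lower numbers for stronger inhibition. Of the compounds shown here, two carry numbers so far. Compound 1 `Cc1ccccc1Nc1nc(N)nc(CN(C)Cc2cccc(Cl)c2)n1` gives 7800 nM in this assay. Compound 2 `CCCCCCN(CS(=O)(=O)c1ccc(C)cc1)CS(=O)(=O)c1ccc(C)cc1` gives 1700 nM in this assay, the lower of the two numbers; the gap to compound 1 lies beyond the usual scatter, so compound 2 is the stronger of the pair on this read-out. Compound 1 and compound 2 differ from each other in many places at once, so their pair says nothing about any single change.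

Compound 3 `Cc1ccc(S(=O)(=O)CN(Cc2ccccc2)CS(=O)(=O)c2ccc(C)cc2)cc1` is not yet measured. It differs from compound 2 in one place: phenyl in place of pentyl on a saturated chain carbon bound to an amine nitrogen. Going by the values given here, no measured pair shows this change, so the size of the step is open. Expected is a change that stays close to the usual scatter, with a slight lean toward a lower number, the step being estimated as a 1.2-fold lower number from compound 2 to compound 3 (0.08 log units; within the scatter). Compound 3 is expected to give 1400 nM in this assay, with a range from 400 nM to 5000 nM.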

Compound 3, inhibition constant: 7500 nM
Beside the measured number, compound 3's estimate is 5.4-fold (0.73 log units) below it; the measured number lies above the stated range.
By their numbers in this assay, from the lowest: compound 2; then compounds 3 and 1 (each within the scatter of the next).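

In this assay, going by these compounds alone, the group on the amine nitrogen now has a measured effect: hexyl to benzyl gives a 4.4-fold higher number from compound 2 to compound 3 (0.64 log units; beyond the scatter) and thereby shows that this position is sensitive to the change, which the earlier compounds, differing in many places at once, could not show. Neither pentyl nor phenyl carries a hydrogen-bond donor, a hydrogen-bond acceptor or a net charge, so on these counts the pair differs in the exchange of an open chain for a six-membered aromatic ring, and the hexyl compound holds the lower number. Nothing available bears on what lies behind this step.

One pair cannot tell whether the higher number follows from the aromatic ring itself or from the shape of the substituent as a whole, and cyclohexylmethyl or phenethyl on the nitrogen would separate these readings. How far the chain can vary also remains open, since neither a shorter chain such as butyl nor a longer one such as octyl appears among the compounds shown, and neither does a chain ending in an amine or a carboxylic acid.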